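Phenylsulfonyl for Fluorophenoxy on a Shared Amide Core

The source may report more compounds than this note shows. Statements on the series, on what has been measured and on what is new or still open speak of the compounds shown alone.

Compound 2 `COc1cc(OC)c2c(=O)cc(C(=O)Nc3ccc(Oc4ccc(F)cc4)cc3)[nH]c2c1` carries a 4-fluorophenoxy group on its outer aromatic ring. In a functional assay on KOPN-8 cells (Homo sapiens) for antiproliferative activity, with a stated time of 72 h (on this read-out higher numbers stand for an effect only at larger amounts of compound and lower numbers for an effect already at smaller amounts), compound 2 reaches only the assay limit, > 50000 nM, so no number is known for it. Compound 1 `COc1ccc(-c2cc(=O)c3c(OC)cc(OC)cc3n2S(=O)(=O)c2ccc(F)cc2)cc1` likewise stops at a limit in this assay, > 65500 nM. Both values shown are therefore limits, as noted in the limit of > 50000 nM in this assay, at which 1 of the 2 values shown sits, and (the limit of > 65500 nM in this assay, at which 1 of the 2 values shown sits), and compound 2 stands at one of them, with no measured number to rank it against.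

Compound 3 `COc1cc(OC)c2c(=O)cc(C(=O)Nc3ccc(S(=O)(=O)c4ccccc4)cc3)[nH]c2c1` differs from compound 2 by a single change: phenylsulfonyl in place of 4-fluorophenoxy on an aromatic carbon, para to a large group. Among the compounds with values here, no step between measured compounds exists here to guide the size or direction of this change. For compound 3 the estimated step that the limit leaves unreadable from compound 2 to compound 3 is none beyond the scatter. Compound 3 is expected to give about 60000 nM in this assay, within a range from 15000 nM to 200000 nM, and most likely it will again be reported only as a limit.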

Compound 3, half-maximal effective concentration: > 70600 nM
Compound 3 gave a limit, no number; the forecaster's own chance of this, stated with the estimate: 75%; at least 1.1-fold (0.07 log units) between middle value and limit.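

No step can be read between compound 2 and compound 3, since each stands only at a limit in this assay, not at a number. The compounds shown leave open whether phenylsulfonyl in place of 4-fluorophenoxy changes the antiproliferative effect at all, and at what amount any of them would act.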